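Replacing the sulfonyl group in compound 2

The source may hold more compounds than are shown below. What is called first, only, known or untested is meant among the compounds shown, and "the series" means these compounds.

Going by the values given here, in a physicochemical assay for solubility, in phosphate buffer, with a stated time of 24 h, at pH 7.4, tested at 100 uM (on this read-out lower numbers stand for lower solubility and higher numbers for higher solubility), compound 1 `CCC(=O)N1CCC(S(=O)(=O)c2ccc(CNC(=O)N3Cc4ccncc4C3)cc2)CC1` gives 216000 nM and compound 2 `O=C(NCc1ccc(S(=O)(=O)C2CCN(C3COC3)CC2)cc1)N1Cc2ccncc2C1` gives 121000 nM, which places compound 2 within the scatter of the only other number. Compound 3 `O=C(NCc1ccc(S(=O)(=O)N2CCC[C@@H](O)C2)cc1)N1Cc2ccncc2C1` carries 3-hydroxypiperidin-1-yl in place of 1-(oxetan-3-yl)piperidin-4-yl on a sulfonyl sulfur. Among the compounds with values here, the one measured step, oxetan-3-yl in place of propanoyl on an amine nitrogen in a ring, is a 1.8-fold lower number from compound 1 to compound 2 (0.25 log units; within the scatter) and bears only loosely, since no measured step covers this swap. No change beyond the scatter is therefore expected in this assay. The expected step is a 1.0-fold higher number from compound 2 to compound 3 (0.01 log units; within the scatter). Compound 3 is estimated at 125000 nM, within an expected range from 50000 nM to 230000 nM.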

Compound 3, solubility: 216000 nM
Estimate against measurement, compound 3: 1.7-fold (0.24 log units) below; measured number inside the range.
By their numbers in this assay, from the lowest: compounds 2, 1 and 3 (each within the scatter of the next).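

In this assay the whole group on the sulfonyl sulfur can be exchanged without leaving the scatter. Going by these compounds alone, putting 3-hydroxypiperidin-1-yl in place of 1-(oxetan-3-yl)piperidin-4-yl gives a 1.8-fold higher number from compound 2 to compound 3 (0.25 log units; within the scatter) and putting it in place of 1-propanoylpiperidin-4-yl gives no change at the digits printed from compound 1 to compound 3 (within the scatter) so the earlier step on the ring nitrogen is no longer the only change here that stays within the scatter. No evidence is at hand on what lies behind these numbers.

Still open, going by these compounds, is how a morpholine ring or a carboxylic acid at this place would read in this assay and whether the mirror-image form of 3-hydroxypiperidin-1-yl would match compound 3.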